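A few compounds are considered here, and "the series" means these few. Any claim that something is new, unique, unknown or untested is made for them only; others in the source may bear on it.

Series in a functional assay on QGY-7703 cells (Homo sapiens) for cytotoxicity, read by MTT assay, with a stated time of 24 h; a higher number here means a weaker inhibitor, a lower number a stronger inhibitor:
- compound 1 `O=C1/C(=C/c2cccnc2)CN(S(=O)(=O)c2ccccc2)C/C1=C\c1ccccc1F`: 4800 nM
- compound 2 `O=C1/C(=C/c2cccnc2)CN(S(=O)(=O)c2ccc(F)cc2)C/C1=C\c1ccccc1F`: 15300 nM
- compound 3 `O=C1/C(=C/c2cccnc2)CN(S(=O)(=O)c2ccc(Cl)cc2)C/C1=C\c1ccccc1F`: not yet measured

Within the data shown here, of the two numbers so far in this assay, compound 2 has the higher, at 15300 nM, which makes it the weaker inhibitor. Going on to compound 3 means (chloro in place of fluoro on an aromatic carbon), in words chloro in place of fluoro on an aromatic carbon, para to a large group. Among the measured compounds shown here, one measured step bears on this: a 3.2-fold higher number from compound 1 to compound 2 (0.50 log units; beyond the scatter), where fluoro took the place of hydrogen at that same carbon. For the measured compounds named here, no chloro compound has been measured, so the direction rests on little. A halogen swap is expected to move the number less than that step did, perhaps slightly downward, and probably within the scatter. The expected change is a 1.3-fold lower number from compound 2 to compound 3 (0.11 log units; within the scatter). For compound 3 the estimate is 12000 nM, with an expected range of 5000 nM to 28000 nM.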

Compound 3, half-maximal inhibitory concentration: 12100 nM
For compound 3 the middle estimate is 1.0-fold (0.00 log units) below the measured one; measured number inside the range.
By their numbers in this assay, from the lowest: compound 1; then compounds 3 and 2 (each within the scatter of the next).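

In this assay, (4-chlorophenyl)sulfonyl in place of (4-fluorophenyl)sulfonyl gives a 1.3-fold lower number from compound 2 to compound 3 (0.10 log units; within the scatter), so at this carbon the two halogens are not told apart. Chloro in place of hydrogen at the same carbon gives a 2.5-fold higher number from compound 1 to compound 3 (0.40 log units; beyond the scatter), which shows that the move away from compound 1 does not belong to fluoro alone: both halogen compounds lie on the weaker side of compound 1, and neither goes against this. Nothing at hand gives a cause for either step.

Open, on these data alone, is whether the weaker number follows any group at this carbon or only a halogen; a methoxy group, an amine or a carboxylic acid there would separate the two. Also open, as far as these compounds go, is whether other positions on this ring behave the same way.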